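This account rests on a few compounds, and the source may have more. Where it says the series, first, only, none or still open, it means among the compounds named here.

Compound 1 (`COc1ccc(-n2c(SC(C)C(=O)Nc3ncc(C(F)(F)F)cc3Cl)nc3ccccc32)cc1`) is a benzimidazole-type thioether whose amide is carried by a 3-chloro-5-(trifluoromethyl)pyridin-2-yl group. In an ADME assay on Vero cells (Chlorocebus sabaeus) for cytotoxicity, read by MTT assay, with a stated time of 24 h (a higher number here means that more compound is tolerated, a lower number that less compound is tolerated), compound 1 gives 9200 nM, the only numerical result in this set. Compound 2 (`COc1ccc(-n2c([S+]([O-])C(C)C(=O)Nc3ccc(C)cc3Cl)nc3ccccc32)cc1`), a sulfoxide with a different aryl amide, is reported in this assay only as a limit, > 75000 nM, and not as a measured number; this is the point noted as the limit of > 75000 nM in this assay, at which 1 of the 2 values shown sits. Among the compounds with values here, because one of the two values is a limit, no step between measured compounds can be drawn from these data.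

Compound 3 (`COc1ccc(-n2c(SC(C)C(=O)Nc3ncc(C)cc3Cl)nc3ccccc32)cc1`) differs from compound 1 at one place: methyl in place of trifluoromethyl on an aromatic carbon, turning the 3-chloro-5-(trifluoromethyl)pyridin-2-yl group into 3-chloro-5-methylpyridin-2-yl. Within the data shown here, no measured pair shows this change, so the size of its effect in this assay is open. The step from compound 1 to compound 3 is expected to be modest and, if anything, toward a larger value, about a 1.6-fold higher number from compound 1 to compound 3 (0.21 log units; within the scatter). Compound 3 is therefore expected to give roughly 15000 nM in this assay, within a range of 5000 nM to 60000 nM.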

Compound 3, half-maximal cytotoxic concentration: 880 nM
Beside the measured number, compound 3's estimate is 17-fold (1.23 log units) above it; the measured number lies below the stated range.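

Within the data shown here, this is the first measured step in the set: a 10-fold lower number from compound 1 to compound 3 (1.02 log units; beyond the scatter) in this assay, so that less compound is tolerated once methyl stands in place of trifluoromethyl. The aromatic carbon two atoms from the ring nitrogen is thus shown to be a place where one change of substituent, with the rest of compound 1 kept, moves this read-out beyond the usual scatter, which no earlier pair could show. Nothing measured here gives a property of either group that would account for the step.

From the compounds shown here alone, whether a hydrogen, an ethyl group or a nitrile on this same carbon would fall nearer to compound 1 or to compound 3 remains open, so one step cannot yet describe a trend at this position. Also open, going by these compounds, is whether methyl in place of trifluoromethyl gives a step of similar size when the thioether is replaced by a sulfoxide, or when the chloro group on this ring is replaced by a fluoro group.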